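The source may report more compounds than this note shows. Statements on the series, on what has been measured and on what is new or still open speak of the compounds shown alone.

Measured so far:

Compound 1, `CCOc1ccc(NCN2C(=O)c3ccccc3C2=O)cc1`: 100%
Compound 2, `COc1ccc(NCN2C(=O)c3cccc(N)c3C2=O)cc1`: 95.6%
Compound 3, `COc1ccc(NCN2C(=O)c3cccc(NC(=O)c4ccccc4)c3C2=O)cc1`: 99.5%

All three were tested in an assay on isolated protein for inhibition of ribosomal protein S6 kinase alpha-2 (Homo sapiens), read by fluorescence, with a stated time of 20 min, tested at 10 uM; a lower number here means less inhibition, a higher number more inhibition at the concentration tested (going by the name of the read-out). Compound 3 stands second highest of the three numbers, with compound 1 nearest and compound 2 furthest, both gaps within the scatter. Compound 4, `CCOc1ccc(NCN2C(=O)c3cccc(NC(=O)c4ccccc4)c3C2=O)cc1`, is the unmeasured compound; it differs from compound 3 by methyl in place of hydrogen on a saturated chain carbon bound to an oxygen on an aromatic ring.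

Among the compounds with values here, no measured step covers this change alone. The only listed step, a number 3.9 percentage points higher from compound 2 to compound 3 (within the scatter), concerns a different part of the molecule. Compound 1, which carries an ethoxy group, and compound 3, which carries a methoxy group, show values within the scatter of each other, though they also differ elsewhere. Within the data shown here, every compound so far gives a number near the top of the scale in this assay, so no step beyond the scatter is expected.

Compound 4 is therefore expected to give 99%, between 92% and 100%, an expected step of a number 0.5 percentage points lower from compound 3 to compound 4 (within the scatter).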

Compound 4, a percentage reported as inhibition, at one concentration (the size of the read-out at that concentration, not a potency): 105%
Compound 4: the middle estimate sits 6 percentage points below what was measured, outside the stated range (above it).
By their numbers in this assay, from the lowest: compounds 2, 3, 1 and 4 (each within the scatter of the next).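

With the benzamido group present, methoxy to ethoxy gives a number 5.5 percentage points higher from compound 3 to compound 4 (within the scatter) in this assay and shows that this chain carbon accepts a methyl with no change that can be told from scatter. With ethoxy already in place, adding benzamido gives a number 5 percentage points higher from compound 1 to compound 4 (within the scatter) and likewise shifts nothing readable, so the two groups can sit on one molecule. No measured evidence accounts for either step.

All four numbers lie near the top of the scale, so a single test concentration leaves any real differences among them unresolved. From the compounds shown here alone, whether a longer chain such as propoxy, or an amine in place of the ethoxy group, would keep the number this high stays open.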